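From methoxy to hydrogen: compound 2 to compound 3

The compounds below may be only part of what the source reports. "The series", "measured", "known", "first", "only" and "open" are said of these compounds alone.

In a toxicity assay on THP-1 cells (Homo sapiens) for inhibition (on this read-out higher numbers stand for lower toxicity in this test and lower numbers for higher toxicity in this test), compound 1 `Cn1c(-c2ccccc2)cnc1NC(=O)c1ccc(Br)cc1` gives > 100000 nM, which is a limit of the assay and not a number. Compound 2 `COc1ccc(-c2cnc(NC(=O)C3CCCCC3)n2C)cc1` gives > 100000 nM, which is likewise a limit. Compound 2 therefore has no exact value, and the data so far show (the limit of > 100000 nM in this assay, at which 2 of the 2 values shown sit).

Compound 3 `Cn1c(-c2ccccc2)cnc1NC(=O)C1CCCCC1` differs from compound 2 in one place: hydrogen in place of methoxy on an aromatic carbon. Hydrogen stands in place of methoxy on an aromatic carbon, para to a large group. Within the data shown here, no step between measured compounds is available to gauge this change. In this assay no shift beyond the scatter is expected, and the estimated step is a number no higher from compound 2 to compound 3 (the limit leaves the size open). The result will most likely again be reported only as a limit. For compound 3 the expected value is 100000 nM, with an estimated range from 40000 nM to 200000 nM.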

Compound 3, half-maximal cytotoxic concentration: > 100000 nM
Compound 3 ended at the assay's limit; the forecaster's own chance of this, stated with the estimate: 85%; the middle value sits exactly at the limit.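

Compound 1, compound 2 and compound 3 all stand at a limit in this assay, so the steps from compound 2 to compound 3 and from compound 1 to compound 3 cannot be read. The compounds shown leave open whether either change shifts the read-out at all: the limit of > 100000 nM in this assay, at which 3 of the 3 values shown sit.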